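Halide swap on the phthalimide-bearing aryl, compound 2 to 4

The compounds below may be only part of what the source reports. "The series", "measured", "known", "first", "only" and "open" are said of these compounds alone.

Measured so far:
compound 1 `O=C(Nc1cccc(F)c1CN1C(=O)c2ccccc2C1=O)c1ccccn1` — > 100000 nM
compound 2 `COc1ccc2c(c1OC)C(=O)N(Cc1cc(Br)ccc1NC(=O)c1ccccn1)C2=O` — > 100000 nM
compound 3 `O=C(Nc1ccc(Cl)cc1CN1C(=O)c2ccccc2C1=O)c1cccnc1` — 35000 nM

In an assay on CHO cells for positive allosteric modulation of metabotropic glutamate receptor 5 (Homo sapiens), read by FLIPR (a lower number here means that less compound is needed, a higher number that more compound is needed for the effect), compound 2 gives only a limit of the assay, > 100000 nM, and no number. Compound 1 likewise sits at a limit in this assay with > 100000 nM. Going by the values given here, compound 3, which differs from both in more than one place, is the only member with a measured number, 35000 nM; no step to it is counted here, so only the values themselves can be compared.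

Compound 4 `COc1ccc2c(c1OC)C(=O)N(Cc1cc(Cl)ccc1NC(=O)c1ccccn1)C2=O` is compound 2 with the change (chloro in place of bromo on an aromatic carbon), that is chloro in place of bromo on an aromatic carbon. The two halides are counted as a single heavy atom each, with no change in rings, donors, acceptors or charge. Among the compounds with values here, with compound 2 at a limit, no measured step sets a scale for this exchange; the step of a number no higher from compound 2 to compound 4 (the limit leaves the size open) is expected to be none beyond the scatter. Compound 4 is therefore expected around 100000 nM, between 30000 nM and 300000 nM, and a reading that is again only a limit is the more likely outcome because of the limit of > 100000 nM in this assay, at which 2 of the 3 values shown sit.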

Compound 4, half-maximal effective concentration: > 100000 nM
Compound 4: no number, only a limit; the forecaster's own chance of this, stated with the estimate: 70%; the middle value lies on the limit itself.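

In this assay compound 4 gives > 100000 nM, a limit and not a number. Compound 2 likewise gives only a limit, > 100000 nM, so no step can be read between compound 2 and compound 4. On these data alone, whether chloro in place of bromo changes the read-out at all remains open.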